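Cytotoxicity notes on the biaryl amide series, compound 4

A few compounds are considered here, and "the series" means these few. Any claim that something is new, unique, unknown or untested is made for them only; others in the source may bear on it.

compound 1 `CCOC(=O)CCCCCOc1cccc(CN(C(=O)c2ccc(-c3cccc(C(C)=O)c3)cc2)C(C)C)c1`: in an ADME assay on HepG2 cells (Homo sapiens) for cytotoxicity, read by CellTiter-Glo and resazurin assay, with a stated time of 72 h (a higher number here means that more compound is needed for the effect, a lower number that less compound is needed), compound 1 gives only a limit, > 26000 nM
compound 2 `CCOC(=O)CCCCCOc1cccc(CN(C(=O)c2ccc(-c3ccoc3)cc2)C(C)C)c1`: in this assay compound 2 gives only a limit, > 26000 nM
compound 3 `CCOC(=O)CCCCCOc1cccc(CN(C(=O)c2ccc(-c3cccc(CC(=O)O)c3)cc2)C(C)C)c1`: in this assay compound 3 gives only a limit, > 26000 nM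

Compound 3 therefore stands nowhere on a scale: its value is a limit, and the two other values shown are limits as well, all sitting at the limit of > 26000 nM in this assay, at which 3 of the 3 values shown sit. The steps between the measured compounds cannot be read for size: a step that the two limits leave unreadable from compound 1 to compound 2, a step that the two limits leave unreadable from compound 1 to compound 3 and a step that the two limits leave unreadable from compound 2 to compound 3 are all hidden by the limits on both sides.

Compound 4 `CCOC(=O)CCCCCOc1cccc(CN(C(=O)c2ccc(-c3cccc([N+](=O)[O-])c3)cc2)C(C)C)c1` is the next member. The change from compound 3 is nitro in place of carboxymethyl on an aromatic carbon. Among the measured compounds shown here, no measured step bears on it with a readable size, since every step ends at a limit. The only guide is that all three shown values sit at the limit of > 26000 nM in this assay, at which 3 of the 3 values shown sit, so the expectation for compound 4 is that it too stays at the limit, with the estimated step that the limit leaves unreadable from compound 3 to compound 4 amounting to nothing beyond the scatter. Compound 4 is thus estimated at 30000 nM in this assay, with a range from 15000 nM to 60000 nM.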

Compound 4, half-maximal effective concentration: > 26000 nM
Compound 4 was reported as a limit; the forecaster's own chance of this, stated with the estimate: 85%; the middle value is on the limit's open side.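

In this assay compound 4 gives only a limit, > 26000 nM. Among the compounds shown here, no step from compound 1, compound 2 or compound 3 to compound 4 can be read for size. As far as these compounds go, whether these four compounds differ from one another at all stays open: the limit of > 26000 nM in this assay, at which 4 of the 4 values shown sit.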